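This account rests on a few compounds, and the source may have more. Where it says the series, first, only, none or still open, it means among the compounds named here.

Measured compounds:
compound 1, `O=C(NCc1ccccc1)c1cn(-c2ccccc2)nc1-c1ccncc1`: in a functional assay on MDA-MB-231 cells (Homo sapiens) for cytotoxicity, read by MTT assay, with a stated time of 48 h (on this read-out higher numbers stand for weaker inhibition and lower numbers for stronger inhibition), compound 1 gives > 100000 nM, a limit of the assay rather than a number.
compound 2, `CCc1ccc(OC(=O)c2cn(-c3ccccc3)nc2-c2ccncc2)cc1`: in this assay compound 2 gives > 100000 nM, likewise a limit of the assay.

Compound 2 therefore stands nowhere definite on the numbers shown: all that is known is that its potency does not reach the limit. Going by the values given here, the single measured step, a step that the two limits leave unreadable from compound 1 to compound 2, has no readable size because the limit of > 100000 nM in this assay, at which 2 of the 2 values shown sit, holds both of its ends.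

Compound 3, `Cc1ccc(C(C)C)c(OC(=O)c2cn(-c3ccccc3)nc2-c2ccncc2)c1`, differs from compound 2 by 2-isopropyl-5-methylphenyl in place of 4-ethylphenyl on an oxygen next to a carbonyl group. Among the compounds with values here, no measured step touches this part of the molecule; the one step known changed the group on the carbonyl carbon, not the aryl group on the oxygen, and even that step is unreadable. There is thus no measured ground for expecting compound 3 to move away from the limit in this assay, and the expected step of a number no higher from compound 2 to compound 3 (the limit leaves the size open) is taken as no change beyond the scatter. Compound 3 is estimated at 100000 nM, within a range from 30000 nM to 300000 nM, most probably again reported only as a limit.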

Compound 3, half-maximal inhibitory concentration: > 100000 nM
Compound 3 gave a limit, no number; the forecaster's own chance of this, stated with the estimate: 75%; the middle value lies on the limit itself.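

Neither the step from compound 1 to compound 2 nor the step from compound 2 to compound 3 can be given a size, because each compound gives only a limit, not a number: the limit of > 100000 nM in this assay, at which 3 of the 3 values shown sit.

The compounds shown leave open how strongly any of the three acts on these cells, and whether either change alters that at all.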